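The source may report more compounds than this note shows. Statements on the series, on what has been measured and on what is new or still open speak of the compounds shown alone.

Measured in a functional assay on KARPAS-299 cells (Homo sapiens) for antiproliferative activity, read by MTT assay, with a stated time of 4 h; on this read-out higher numbers stand for weaker inhibition and lower numbers for stronger inhibition:
Compound 1 `COc1cc(-n2cccc2C(=O)N2CCCCC2)ccc1Nc1ncc(Cl)c(Nc2ccccc2NS(C)(=O)=O)n1`: 1040 nM
Compound 2 `COc1cc(-n2cccc2C(=O)N2CCCC2)ccc1Nc1ncc(Cl)c(Nc2ccccc2NS(C)(=O)=O)n1`: 870 nM

Compound 2 and compound 1 are separated only by a 1.2-fold lower number from compound 1 to compound 2 (0.08 log units; within the scatter), a gap within the scatter, so on the numbers shown the two compounds stand together rather than apart. Compound 3 `COc1cc(-n2cccc2C(=O)N2CCC(C)CC2)ccc1Nc1ncc(Cl)c(Nc2ccccc2NS(C)(=O)=O)n1` carries the change (4-methylpiperidin-1-yl in place of pyrrolidin-1-yl on a carbonyl carbon). Among the measured compounds shown here, the one measured step that bears on this place, from the six-membered to the five-membered ring on the same carbonyl carbon, was a 1.2-fold lower number from compound 1 to compound 2 (0.08 log units; within the scatter) and did not leave the scatter; the methyl group on the six-membered ring of compound 3 has no counterpart among the measured pair, so nothing indicates its effect. Compound 3 is therefore expected to show no step beyond the scatter, a 1.1-fold higher number from compound 2 to compound 3 (0.06 log units; within the scatter), in this assay. The estimate for compound 3 in this assay is 1000 nM, within a range of 400 nM to 2500 nM.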

Compound 3, half-maximal inhibitory concentration: 1370 nM
The estimate for compound 3 lay 1.4-fold (0.14 log units) below the measured number; measured number inside the range.
By their numbers in this assay, from the lowest: compounds 2, 1 and 3 (each within the scatter of the next).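

In this assay, the methyl group on a saturated ring carbon now has a measured reading: a 1.3-fold higher number from compound 1 to compound 3 (0.12 log units; within the scatter), so placing it on the six-membered ring does not set compound 3 apart from compound 1. The full exchange of pyrrolidin-1-yl for 4-methylpiperidin-1-yl on the carbonyl carbon gives a 1.6-fold higher number from compound 2 to compound 3 (0.20 log units; within the scatter), also within the scatter, so all three compounds stand together and neither ring size nor this methyl group has yet separated them here. No measurement shown accounts for this result.

The compounds shown leave open whether a ring with a second hetero atom, such as morpholin-4-yl, would stay within the scatter on this carbonyl carbon. As far as these compounds go, it also remains open whether an open-chain dimethylamino group, or a hydroxyl or amine in place of the methyl, would do the same.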